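The compounds below may be only part of what the source reports. "The series", "measured", "known", "first", "only" and "open" are said of these compounds alone.

Among the measured compounds shown here, in a functional assay on HeLa cells (Homo sapiens) for antiproliferative activity, read by MTT assay (a higher number here means a weaker inhibitor, a lower number a stronger inhibitor), compound 1 `COc1ccc(-c2ccnc(Nc3ccc([N+](=O)[O-])cc3)n2)cc1` gives 980 nM, the lowest of the three numbers so far, while compound 2 `O=[N+]([O-])c1ccc(Nc2nccc(-c3ccc(Br)cc3)n2)cc1` gives 25700 nM and compound 3 `O=[N+]([O-])c1ccc(Nc2nccc(-c3ccc(F)cc3)n2)cc1` gives 3510 nM. Compound 4 `COc1ccc(-c2ccnc(Nc3ccc(Cl)cc3)n2)cc1` keeps the methoxy group of compound 1 and alters another group: chloro in place of nitro on an aromatic carbon. For the measured compounds named here, no measured step touches the nitro group, so the evidence is indirect. The methoxy group was replaced instead, giving a modest step of a 3.6-fold higher number from compound 1 to compound 3 (0.55 log units; beyond the scatter) and a large one a 26-fold higher number from compound 1 to compound 2 (1.42 log units; beyond the scatter), and swapping bromo for fluoro gave a modest step of a 7.3-fold lower number from compound 2 to compound 3 (0.86 log units; beyond the scatter). A modest rise is therefore expected, an estimated 2.6-fold higher number from compound 1 to compound 4 (0.41 log units; beyond the scatter), with real uncertainty even in direction. Compound 4 is estimated at 2500 nM, within an expected range of 500 nM to 12000 nM.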

Compound 4, half-maximal inhibitory concentration: 310 nM
The estimate for compound 4 lay 8.1-fold (0.91 log units) above the measured number; the whole stated range lies above it.
By their numbers in this assay, from the lowest: compound 4; then compound 1; then compound 3; then compound 2.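

Among the compounds shown here, until now only the methoxy group had changed, so this is the first direct reading at the place that holds the nitro group: in this assay, chloro in place of nitro gives a 3.2-fold lower number from compound 1 to compound 4 (0.50 log units; beyond the scatter), a step beyond the scatter. In this pair, the nitro group is therefore not needed for activity, and a single chlorine atom does better. Nothing measured here explains the shift. As far as these compounds go, how an amine or a carboxylic acid would fare at this place remains open. So does whether chloro would bring a similar drop alongside fluoro or bromo instead of methoxy.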